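From ethyl to 4-fluorophenyl on a sulfonyl sulfur

The source may hold more compounds than are shown below. What is called first, only, known or untested is meant among the compounds shown, and "the series" means these compounds.

Compound 1 `CCS(=O)(=O)N1CCC2(CC1)OOC1(CCCC1)OO2`: > 100 ug/mL (a limit)
Compound 2 `CCCS(=O)(=O)N1CCC2(CC1)OOC1(CCCCC1)OO2`: > 100 ug/mL (a limit)

In a functional assay on Huh-7 cells (Homo sapiens) for cytotoxicity, read by MTT assay, with a stated time of 72 h (a lower number here means that less compound is tolerated, a higher number that more compound is tolerated), compound 1 gives > 100 ug/mL as a limit and not as a number. Compound 2 gives > 100 ug/mL as a limit too. Compound 1 therefore stands on the limit of > 100 ug/mL in this assay, at which 2 of the 2 values shown sit, and has no exact value from which to measure a change.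

Compound 3 `O=S(=O)(c1ccc(F)cc1)N1CCC2(CC1)OOC1(CCCC1)OO2` keeps the core of compound 1 but carries 4-fluorophenyl in place of ethyl on a sulfonyl sulfur and so brings in one six-membered aromatic ring of carbon only. For the measured compounds named here, no measured pair shows what such a change does. The expectation therefore rests on compound 1 with > 100 ug/mL as its limit. No step beyond the usual scatter is expected, and the assay may well report only a limit again. The expected change is an at least 1.1-fold lower number from compound 1 to compound 3 (0.04 log units; that floor lies within the scatter) and carries little weight as a direction. For compound 3 the estimated value is 90 ug/mL with an expected range from 35 ug/mL to 150 ug/mL in this read-out.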

Compound 3, half-maximal cytotoxic concentration: > 100 ug/mL
Compound 3: a limit, no number; the forecaster's own chance of this, stated with the estimate: 65%; at least 1.1-fold (0.04 log units) between middle value and limit.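

In this assay compound 3 gives > 100 ug/mL, a limit and not a number. No step can be read between compound 1 and compound 3, as both stand at a limit: the limit of > 100 ug/mL in this assay, at which 3 of the 3 values shown sit.

The compounds shown leave open at what concentration any of them would become cytotoxic, and whether 4-fluorophenyl in place of ethyl on a sulfonyl sulfur shifts that concentration at all.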